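The compounds below may be only part of what the source reports. "The series", "measured", "known", "first", "only" and "open" are said of these compounds alone.

In a functional assay on LoVo cells (Homo sapiens) for inhibition, read by MTT assay, with a stated time of 24 h (on this read-out lower numbers stand for stronger inhibition and higher numbers for weaker inhibition), compound 1 `CC1(C)[C@H]2CC[C@]1(C)N(Cc1cn(-c3cccc(F)c3)nn1)C(=O)C2` gives 90 nM. In the same test, compound 2 `COc1ccccc1-n1cc(CN2C(=O)C[C@@H]3CC[C@@]2(C)C3(C)C)nn1` gives 70 nM. Within the data shown here, the only measured step is a 1.3-fold lower number from compound 1 to compound 2 (0.11 log units; within the scatter), with 2-methoxyphenyl in place of 3-fluorophenyl on an aromatic nitrogen, so compound 2 stands level with the one other measured compound. Compound 3 `CC1(C)[C@H]2CC[C@]1(C)N(Cc1cn(-c3ccc(O)cc3)nn1)C(=O)C2` keeps the shared core and again alters only that site: 4-hydroxyphenyl in place of 2-methoxyphenyl on an aromatic nitrogen, which puts 4-hydroxyphenyl in place of 2-methoxyphenyl on an aromatic nitrogen. Among the measured compounds shown here, the one earlier exchange at this site is a modest guide, and no measured compound carries a 4-hydroxyphenyl group. A change of no size beyond the scatter is therefore expected in this assay, with no direction favoured, and the estimated step is a 1.4-fold higher number from compound 2 to compound 3 (0.15 log units; within the scatter). Compound 3 is expected to give 100 nM, within an estimated range from 30 nM to 350 nM.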

Compound 3, half-maximal inhibitory concentration: 410 nM
Compound 3: middle estimate off by 4.1-fold (0.61 log units), on the low side; measured number outside the range, above it.
By their numbers in this assay, from the lowest: compounds 2 and 1 (each within the scatter of the next); then compound 3.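

The aromatic group on this nitrogen is not freely exchangeable in this assay: 4-hydroxyphenyl brings a 5.9-fold higher number from compound 2 to compound 3 (0.77 log units; beyond the scatter) and likewise a 4.6-fold higher number from compound 1 to compound 3 (0.66 log units; beyond the scatter), so inhibition is weaker than with either earlier group. Compounds 1 and 2 lay within the scatter of each other despite carrying different groups, so only compound 3 shows that a change at this site can shift the result measurably, and it is also the change that brings in a hydrogen-bond donor where 2-methoxyphenyl has none. Nothing available explains the weaker result.

The step changes both the group on the phenyl ring and its place, so the two effects cannot be separated here. A 4-methoxyphenyl or 2-hydroxyphenyl group would help to tell them apart.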